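Aryloxy versus benzyl on the shared core of compound 1

A few compounds are considered here, and "the series" means these few. Any claim that something is new, unique, unknown or untested is made for them only; others in the source may bear on it.

Compound 1 `N[C@@H](COP(=O)(O)OCCCOC(=O)CCc1ccccc1OCc1cccc(Cc2ccccc2)c1)C(=O)O`: 0.077
Compound 2 `Cc1ccccc1Oc1cccc(COc2ccccc2CCC(=O)OCCCOP(=O)(O)OC[C@H](N)C(=O)O)c1`: 0.28
Compound 3 `Cc1cccc(Oc2cccc(COc3ccccc3CCC(=O)OCCCOP(=O)(O)OC[C@H](N)C(=O)O)c2)c1`: 0.29

In an assay on cells for activation of probable G-protein coupled receptor 34 (Mus musculus), with a stated time of 1 h (on this read-out lower numbers stand for smaller maximal responses and higher numbers for larger maximal responses), compound 1 gives the lowest of the three numbers; compound 2 stands a number 0.20 higher from compound 1 to compound 2 (beyond the scatter) and compound 3 stands a number 0.21 higher from compound 1 to compound 3 (beyond the scatter), while the two methylphenoxy analogues differ only a number 0.010 higher from compound 2 to compound 3 (within the scatter). Compound 4 `N[C@@H](COP(=O)(O)OCCCOC(=O)CCc1ccccc1OCc1cccc(Oc2ccc(F)cc2)c1)C(=O)O` changes compound 1 as follows: 4-fluorophenoxy in place of benzyl on an aromatic carbon. The two measured steps from benzyl to a methylphenoxy group, both modest and beyond the scatter, bear directly on this change, and an aryloxy group entering at the same place is therefore expected to raise this assay by a similar modest amount, a number 0.19 higher from compound 1 to compound 4 (beyond the scatter). Compound 4 is estimated at 0.27, in a range from 0.14 to 0.4.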

Compound 4, intrinsic activity: the largest response reached, as a fraction of the reference agonist's: 0.66
Compound 4: the middle estimate sits 0.39 below what was measured; the whole stated range lies below it.
By their numbers in this assay, from the lowest: compound 1; then compounds 2 and 3 (each within the scatter of the next); then compound 4.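

Among these compounds, at this place the aryl group carried on the oxygen counts, not just the aryloxy link replacing benzyl: in this assay there is a number 0.58 higher from compound 1 to compound 4 (beyond the scatter), and changing only that aryl group gives a number 0.38 higher from compound 2 to compound 4 (beyond the scatter) and a number 0.37 higher from compound 3 to compound 4 (beyond the scatter). Among the compounds shown here, the two methylphenoxy groups had stayed within the scatter of each other, so this is the first large separation among the aryloxy groups. The data shown offer no explanation for this rise.

From the compounds shown here alone, whether the fluorine or its ring position carries the rise remains open. A 4-methylphenoxy or a 3-fluorophenoxy group would separate the two.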